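A few compounds are considered here, and "the series" means these few. Any claim that something is new, unique, unknown or untested is made for them only; others in the source may bear on it.

Compound 1, `CC(=O)O[C@@H]1C[C@@H](C)[C@](O)(CCC2=CC(=O)OC2)[C@@]2(C)CCCC(C)(C)[C@H]12`, is known in a functional assay on HCT-116 cells (Homo sapiens) for cytotoxicity, read by MTT assay, with a stated time of 72 h (on this read-out higher numbers stand for weaker inhibition and lower numbers for stronger inhibition), only through a limit of the assay: compound 1 gives < 5 ug/mL. Compound 2, `C[C@@H]1C[C@@H](O)[C@H]2C(C)(C)CCC[C@]2(C)[C@@]1(O)CCC1=CC(=O)OC1`, stands at a limit of the same kind, and in this assay compound 2 gives < 5 ug/mL. Between them lies a step that the two limits leave unreadable from compound 1 to compound 2, since (the limit of < 5 ug/mL in this assay, at which 2 of the 2 values shown sit). Compound 3, `CC(=O)O[C@@H]1C[C@@H](C)[C@](O)(CCc2ccoc2)[C@@]2(C)CCCC(C)(C)[C@H]12`, differs from compound 1 by a group of 5 heavy atoms (4 carbon, 1 oxygen; one five-membered aromatic ring with 1 hetero atom) in place of a group of 6 heavy atoms (4 carbon, 2 oxygen; one five-membered non-aromatic ring with 1 hetero atom), on a saturated chain carbon, two bonds along the chain from a saturated ring carbon. Going by the values given here, no measured step bears on this change, and compound 1 offers only a limit, so the size of the step has no anchor. Compound 3 is therefore expected to give roughly 8 ug/mL, within 2 ug/mL to 30 ug/mL, an estimated at least 1.6-fold higher number from compound 1 to compound 3 (0.20 log units; that floor lies within the scatter).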

Compound 3, half-maximal inhibitory concentration: < 5 ug/mL
Compound 3 was reported as a limit; the forecaster's own chance of this, stated with the estimate: 40%; middle value at least 1.6-fold (0.20 log units) away from the limit.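

No step can be read from compound 1 to compound 3, as both stand at a limit in this assay: the limit of < 5 ug/mL in this assay, at which 3 of the 3 values shown sit.

The compounds shown leave open how compound 1, compound 2 and compound 3 truly compare in this assay, and so what furan-3-yl changes.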